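A few compounds are considered here, and "the series" means these few. Any claim that something is new, unique, unknown or untested is made for them only; others in the source may bear on it.

Compound 1, `N#CC1CN1C(=O)Nc1ccc(Cl)c(Cl)c1`: 5900 nM
Compound 2, `CCOC(=O)c1ccc(NC(=O)N2CC2C#N)cc1`: 5800 nM
Compound 3, `N#CC1CN1C(N)=O`: > 90000 nM

All three have been tested in a functional assay on A-375 cells (Homo sapiens) for inhibition; a lower number here means a stronger inhibitor, a higher number a weaker inhibitor. Compound 1 gives 5900 nM and compound 2 gives 5800 nM; the two numbers lie within the usual scatter of each other, so compound 2 stands level with compound 1 and neither can be called the stronger inhibitor. Compound 3, the bare urea without an aromatic ring, gives > 90000 nM, which is a limit of this assay and not a measured number (the limit of > 90000 nM in this assay, at which 1 of the 3 values shown sits).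

Compound 4, `N#CC1CN1C(=O)Nc1ccc(C(F)(F)F)cc1`, has not yet been measured. It differs from compound 2 in one place: trifluoromethyl in place of ethoxycarbonyl on an aromatic carbon. For the measured compounds named here, no measured pair shows this exchange. What the data do show is that compound 1 at 5900 nM and compound 2 at 5800 nM, which carry different groups on the aromatic ring, sit within the scatter of each other. Since the change from compound 2 to compound 4 keeps the aromatic ring and the urea, the step of a 1.0-fold higher number from compound 2 to compound 4 (0.01 log units; within the scatter) is expected to be small, with no direction beyond the scatter. Compound 4 is therefore estimated at 6000 nM, within a range from 2000 nM to 18000 nM.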

Compound 4, half-maximal inhibitory concentration: 11800 nM
Compound 4: the middle estimate sits 2.0-fold (0.29 log units) below what was measured, and the stated range covers the measured number.
By their numbers in this assay, from the lowest: compounds 2, 1 and 4 (each within the scatter of the next, the first and the last beyond it). At a limit, above all of these: compound 3.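

For the compounds shown here, the exchange of ethoxycarbonyl for trifluoromethyl, on an aromatic carbon para to a group of 8 heavy atoms, gives the first step at this position that can be read in this assay and it is a 2.0-fold higher number from compound 2 to compound 4 (0.31 log units; beyond the scatter) so the group held here does move the number, though only modestly. Ethoxycarbonyl has 5 heavy atoms and 2 hydrogen-bond acceptors, while trifluoromethyl has 4 heavy atoms and 0 hydrogen-bond acceptors, and this single pair cannot tell which of these differences, if any, goes with the step. Nothing in the data shown accounts for the step.

As far as these compounds go, whether a carboxylic acid, an amine or a longer ester chain at this position would give a lower or a higher number stays open. Going by these compounds alone, also open is whether any group here can bring the number clearly lower than compound 2 does with its 5800 nM in this series, since one step gives a direction for only one exchange.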